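Shortening the isopentyl chain on the piperidine nitrogen

The source may report more compounds than this note shows. Statements on the series, on what has been measured and on what is new or still open speak of the compounds shown alone.

Compound 1 `CC(C)CCN1CCC[C@H](Cn2c(CN(C)[C@H]3CCCc4cccnc43)nc3ccccc32)C1` is measured in an ADME assay on HOS cells (Homo sapiens) for cytotoxicity (a lower number here means that less compound is tolerated, a higher number that more compound is tolerated), and gives 2300 nM, the lowest of the three numbers in hand. Compound 2 `CN(Cc1nc2ccccc2n1CC1CNC1)C1CCCc2cccnc21` gives 15000 nM and compound 3 `CN1CC(Cn2c(CN(C)C3CCCc4cccnc43)nc3ccccc32)C1` gives 14000 nM; both gaps to compound 1 lie beyond the scatter, so compound 1 is the least tolerated of the three. Among the compounds with values here, the only measured single step, a 1.1-fold lower number from compound 2 to compound 3 (0.03 log units; within the scatter), concerns a different place and does not exceed the scatter.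

Compound 4 `CC(C)CN1CCC[C@H](Cn2c(CN(C)[C@H]3CCCc4cccnc43)nc3ccccc32)C1` differs from compound 1 by isopropyl in place of isobutyl on a saturated chain carbon bound to an amine nitrogen in a ring. Within the data shown here, no measured step touches this chain, so the expectation rests only on the position of compound 1 relative to compound 2 and compound 3, which carry smaller groups on their ring nitrogen and show higher numbers. A move back toward those values is expected, but of moderate size, so compound 4 is estimated at 3500 nM with a range from 1500 nM to 8000 nM, an expected step of a 1.5-fold higher number from compound 1 to compound 4 (0.18 log units; within the scatter).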

Compound 4, half-maximal cytotoxic concentration: > 2000 nM
Compound 4 ended at the assay's limit (the forecaster's own chance of this, stated with the estimate: 5%); the middle value does not contradict the limit.
By their numbers in this assay, from the lowest: compound 1; then compounds 3 and 2 (each within the scatter of the next).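

In this assay compound 4 gives > 2000 nM and this is a limit of the assay, not a number. The step from compound 1 to compound 4 cannot be read: the limit of > 2000 nM in this assay, at which 1 of the 4 values shown sits. As far as these compounds go, it remains open whether isopropyl in place of isobutyl shifts the number at all, and in which direction.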